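A chloro group in place of hydrogen: expected gain

This account rests on a few compounds, and the source may have more. Where it says the series, first, only, none or still open, it means among the compounds named here.

In a functional assay on the whole organism for antagonist activity, with Mus musculus as the target (a higher number here means that more compound is needed for the effect, a lower number that less compound is needed), compound 3 (`Cc1nnc(CNC(=O)CN)n1-c1ccc(Cl)cc1C(=O)c1ccccc1`) gives 3.02 mg/kg. Compound 1 (`NCC(=O)NCc1nncn1-c1ccc(Cl)cc1C(=O)c1ccccc1`) gives 5.71 mg/kg, and a 1.9-fold lower number from compound 1 to compound 3 (0.28 log units; within the scatter) is a methyl change that offers little guidance here. Compound 2 (`Cc1nnc(CNC(=O)CN)n1-c1ccc(Cl)cc1C(=O)c1ccccc1F`) gives 0.28 mg/kg, far less compound for the same effect.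

Compound 4 (`Cc1nnc(CNC(=O)CN)n1-c1ccc(Cl)cc1C(=O)c1ccccc1Cl`) carries one change, chloro in place of hydrogen on an aromatic carbon, ortho to a large group. The nearest guide is compound 2, which has fluoro in place of that hydrogen, with an 11-fold higher number from compound 2 to compound 3 (1.03 log units; beyond the scatter). Within the data shown here, no chloro compound has been measured, so a somewhat smaller drop is expected, a 6.7-fold lower number from compound 3 to compound 4 (0.83 log units; beyond the scatter). For compound 4 the estimated value is 0.45 mg/kg, with an expected range from 0.12 mg/kg to 1.6 mg/kg.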

Compound 4, dose for half-maximal effect: 0.58 mg/kg
For compound 4 the middle estimate is 1.3-fold (0.11 log units) below the measured one; the range from low to high includes it.
By their numbers in this assay, from the lowest: compound 2; then compound 4; then compounds 3 and 1 (each within the scatter of the next).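

Chloro, ortho to a large group, brings a 5.2-fold lower number from compound 3 to compound 4 (0.72 log units; beyond the scatter) and so shows that the gain at this position is not confined to fluoro. Between the two halogens there is a 2.1-fold higher number from compound 2 to compound 4 (0.32 log units; beyond the scatter) in favour of fluoro, a gap smaller than the gain either one gives over hydrogen. Nothing available explains why either group helps.

As far as these compounds go, whether bromo, methyl or methoxy at this position would keep the gain stays open. So does whether chloro or fluoro would help as much on the core of compound 1, which lacks the methyl group.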